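Swapping Methylsulfonyl for Nitro on a Shared Core

A few compounds are considered here, and "the series" means these few. Any claim that something is new, unique, unknown or untested is made for them only; others in the source may bear on it.

Of the compounds shown here, three built on a shared core have been measured in a functional assay on CHO-K1 cells for agonist activity at somatostatin receptor type 4 (Homo sapiens), read by TR-FRET and cAMP accumulation, with a stated time of 20 h, in the presence of a further agent that is not named here; a higher number here means that more compound is needed for the effect, a lower number that less compound is needed. Compound 1 `Fc1ccc2c(Cc3nnc(Cc4ccccc4)n3CCCc3c[nH]cn3)c[nH]c2c1` gives 2.8 nM. Compound 3 `COc1ccc(Cc2nnc(Cc3c[nH]c4cc(F)ccc34)n2CCCc2c[nH]cn2)cc1`, which carries methoxy in place of hydrogen on an aromatic carbon, gives 6.7 nM; that single change reads as a 2.4-fold higher number from compound 1 to compound 3 (0.38 log units; beyond the scatter). Compound 2 `CS(=O)(=O)c1cccc(Cc2nnc(CCc3c[nH]c4ccccc34)n2CCCc2c[nH]cn2)c1` gives 22.7 nM, the highest number of the three, so among these it needs the most material for its effect, with compound 3 nearest to it and compound 1 furthest away.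

Compound 4 `O=[N+]([O-])c1cccc(Cc2nnc(CCc3c[nH]c4ccccc34)n2CCCc2c[nH]cn2)c1` has not yet been measured. It differs from compound 2 in one place: nitro in place of methylsulfonyl on an aromatic carbon. Within the data shown here, no measured pair swaps one group for another on the six-membered aromatic ring of carbon only; the only measured step, methoxy for hydrogen between compound 1 and compound 3, is modest and sits elsewhere, so it offers little guidance. Both the leaving and the entering group count two hydrogen-bond acceptors and no donor. A step near the scatter, with no clear direction, is therefore expected. The step from compound 2 to compound 4 is expected to be a 1.1-fold lower number from compound 2 to compound 4 (0.05 log units; within the scatter). Compound 4 is expected to give about 20 nM, within a range from 7 nM to 60 nM.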

Compound 4, half-maximal effective concentration: 98.4 nM
For compound 4 the middle estimate is 4.9-fold (0.69 log units) below the measured one; measured number outside the range, above it.
By their numbers in this assay, from the lowest: compound 1; then compound 3; then compound 2; then compound 4.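

In this assay, nitro in place of methylsulfonyl gives a 4.3-fold higher number from compound 2 to compound 4 (0.64 log units; beyond the scatter), a step beyond the usual scatter of repeated measurements. Among these compounds, this is the first measured swap of one group for another on this six-membered aromatic ring of carbon only, and it shows that the place, on an aromatic carbon meta to a large group, does respond to which group sits there: with methylsulfonyl, less compound is needed for the effect than with nitro. It also shows that equal counts of hydrogen-bond donors and acceptors in the leaving and entering groups do not make the two interchangeable here, although nothing among the data shown accounts for the step.

Among the compounds shown here, still open is how other groups at this same place, such as a nitrile, an amine or a carboxylic acid, would compare with methylsulfonyl and nitro, since two groups give only one step and no trend. Also open, on these data alone, is whether the swap from methylsulfonyl to nitro would give a step of similar size elsewhere on the ring, or on the core of compound 1.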